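Trifluoromethoxy in place of cyano on the shared core

This account rests on a few compounds, and the source may have more. Where it says the series, first, only, none or still open, it means among the compounds named here.

In a functional assay on MDA-MB-231 cells (Homo sapiens) for antiproliferative activity, read by MTT assay, with a stated time of 72 h (on this read-out lower numbers stand for stronger inhibition and higher numbers for weaker inhibition), compound 1 `O=S1(=O)C=Cc2ccc(Nc3cccc(C(F)(F)F)c3)cc21` gives 1310 nM as a measured number. Compound 2 `N#Cc1cccc(Nc2ccc3c(c2)S(=O)(=O)C=C3)c1` gives > 10000 nM as a limit of the assay and not a number. Among the compounds with values here, the single measured step, an at least 7.6-fold higher number from compound 1 to compound 2 (0.88 log units; beyond the scatter) and beyond the scatter, puts cyano in place of trifluoromethyl. Compound 3 `O=S1(=O)C=Cc2ccc(Nc3cccc(OC(F)(F)F)c3)cc21` carries trifluoromethoxy in place of cyano on an aromatic carbon, with trifluoromethoxy in place of cyano on an aromatic carbon as the counted change. Within the data shown here, with compound 1 at 1310 nM as the only guide, a lower number is expected in this assay on this change, about as large as that step reversed. An estimated at least 5.0-fold lower number from compound 2 to compound 3 (0.69 log units; beyond the scatter) is expected here. For compound 3 the expected value is 2000 nM with an estimated range of 600 nM to 7000 nM in this series.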

Compound 3, half-maximal inhibitory concentration: 2080 nM
For compound 3 the middle estimate is 1.0-fold (0.02 log units) below the measured one, and the stated range covers the measured number.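

Trifluoromethoxy on this aromatic carbon, meta to a large group, gives a measured number where cyano gives none (an at least 4.8-fold lower number from compound 2 to compound 3 (0.68 log units; beyond the scatter)). Against trifluoromethyl, the same place shows no separation (a 1.6-fold higher number from compound 1 to compound 3 (0.20 log units; within the scatter)), so compound 1 and compound 3 stand level within the scatter. The first step can be read only from one side, as compound 2 stands at a limit and not at a number: the limit of > 10000 nM in this assay, at which 1 of the 3 values shown sits.

Both groups with measured numbers carry fluorine, and only compound 2 carries cyano, so three compounds cannot show what this place requires. As far as these compounds go, how an amine, a carboxylic acid or a methyl group would read here stays open.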